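Swapping the acetyl for a methyl on the aryl ring

The source may hold more compounds than are shown below. What is called first, only, known or untested is meant among the compounds shown, and "the series" means these compounds.

Measured so far in an assay on LM cells for displacement of a labelled ligand from Neuropeptide Y receptor type 5 (Homo sapiens); on this read-out lower numbers stand for stronger inhibition and higher numbers for weaker inhibition:
compound 1 `N#Cc1cccc(C2=NC(c3ccc(F)cc3)(c3ccc(F)cc3)CN2)c1` gives 2.7 nM
compound 2 `O=Cc1cccc(C2=NC(c3ccc(F)cc3)(c3ccc(F)cc3)CN2)c1` gives 8.7 nM
compound 3 `CC(=O)c1cccc(C2=NC(c3ccc(F)cc3)(c3ccc(F)cc3)CN2)c1` gives 44 nM

Three compounds share one core and differ only in the group on the aryl ring. Compound 3 has the highest number of the three: compound 2 lies a 5.1-fold higher number from compound 2 to compound 3 (0.70 log units; beyond the scatter) below it, and compound 1 lies a 16-fold higher number from compound 1 to compound 3 (1.21 log units; beyond the scatter) below it, both beyond the scatter. Within this small set, the cyano group gives the strongest binding and the acetyl group the weakest.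

Compound 4 `Cc1cccc(C2=NC(c3ccc(F)cc3)(c3ccc(F)cc3)CN2)c1` carries the change (methyl in place of acetyl on an aromatic carbon). Among the compounds with values here, no measured step removes the acceptor from this position outright, so the comparison is indirect. Within the data shown here, the steps that bear on it show two things: changing cyano to formyl cost a 3.2-fold higher number from compound 1 to compound 2 (0.51 log units; beyond the scatter), and adding a methyl to the carbonyl carbon cost a 5.1-fold higher number from compound 2 to compound 3 (0.70 log units; beyond the scatter). A smaller group therefore seems to be tolerated better than a larger one, yet every measured group at this position carries an acceptor, and methyl carries none.

Weighing these, the expected step is a 1.6-fold higher number from compound 3 to compound 4 (0.20 log units; within the scatter), a small step in either direction, roughly within the scatter or a little beyond it. Compound 4 is estimated at 70 nM, with a likely range from 20 nM to 250 nM.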

Compound 4, half-maximal inhibitory concentration: 30 nM
Beside the measured number, compound 4's estimate is 2.3-fold (0.37 log units) above it, and the stated range covers the measured number.
By their numbers in this assay, from the lowest: compound 1; then compound 2; then compounds 4 and 3 (each within the scatter of the next).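

In this assay, the step of a 1.5-fold lower number from compound 3 to compound 4 (0.17 log units; within the scatter) shows that this position accepts methyl, which has no hydrogen-bond acceptor, about as well as acetyl, which has one, so having an acceptor here does not by itself set the number. Methyl still falls behind the two other groups, with a 3.4-fold higher number from compound 2 to compound 4 (0.54 log units; beyond the scatter) and an 11-fold higher number from compound 1 to compound 4 (1.05 log units; beyond the scatter), so the earlier hint that a smaller group is simply better does not hold: compound 4 carries the smaller group and goes against it, since it does not come close to compound 1 or compound 2. The data shown offer nothing that explains this ordering of the four groups.

The compounds shown leave open where a plain hydrogen on this aromatic carbon would fall, which would show how much any of these groups adds to or takes from binding. They also leave open whether an amine, a carboxylic acid or a longer chain such as ethyl would sit with cyano at the strong end of this short series or with acetyl and methyl at the weak end.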